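Back From an Aminopropylamino Group to a Sulfonate Ester

The compounds below may be only part of what the source reports. "The series", "measured", "known", "first", "only" and "open" are said of these compounds alone.

Compound 3, `NCCCNc1c(C(=O)NCc2ccc(F)cc2)nc(Br)c2cccnc12`, is the only one of the three measured compounds with a definite number: in a functional assay on HCT-116 cells (Homo sapiens) for cytotoxicity, read by MTT assay, with a stated time of 72 h (on this read-out lower numbers stand for stronger inhibition and higher numbers for weaker inhibition), compound 3 gives 18000 nM. Compound 1, `CS(=O)(=O)Oc1c(C(=O)NCc2ccc(F)cc2)nc(Br)c2cccnc12`, reaches only a limit of the assay in this assay, reported as > 20000 nM. Compound 2, `NCCNc1c(C(=O)NCc2ccc(F)cc2)nc(Br)c2cccnc12`, likewise stops at a limit in this assay, reported as > 20000 nM. The step of an at least 1.1-fold lower number from compound 1 to compound 3 (0.04 log units; that floor lies within the scatter) is therefore only a floor, and so is an at least 1.1-fold lower number from compound 2 to compound 3 (0.04 log units; that floor lies within the scatter), while a step that the two limits leave unreadable from compound 1 to compound 2.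

Compound 4, `Cc1ccc(S(=O)(=O)Oc2c(C(=O)NCc3ccc(F)cc3)nc(Br)c3cccnc23)cc1`, is not yet measured. It differs from compound 3 as follows: ((4-methylphenyl)sulfonyl)oxy in place of (3-aminopropyl)amino on an aromatic carbon. The change brings back a sulfonyloxy group of the kind carried by compound 1, now a ((4-methylphenyl)sulfonyl)oxy rather than a (methylsulfonyl)oxy. Going by these compounds, the step that bears most directly on this is an at least 1.1-fold lower number from compound 1 to compound 3 (0.04 log units; that floor lies within the scatter), read in reverse, and its size stays unknown because of the limit of > 20000 nM in this assay, at which 2 of the 3 values shown sit. Compound 3 itself sits close to that limit. The expectation is therefore that compound 4 shows a step of a 1.4-fold higher number from compound 3 to compound 4 (0.14 log units; within the scatter) in this assay, most likely ending at the limit rather than at a number. The estimate for compound 4 is 25000 nM, with a range from 10000 nM to 60000 nM.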

Compound 4, half-maximal inhibitory concentration: > 20000 nM
Compound 4: no number, only a limit (the forecaster's own chance of this, stated with the estimate: 70%); the middle value does not contradict the limit.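

In this assay, going by these compounds, putting ((4-methylphenyl)sulfonyl)oxy in place of (3-aminopropyl)amino on this aromatic carbon gives an at least 1.1-fold higher number from compound 3 to compound 4 (0.04 log units; that floor lies within the scatter), so this step is a floor and its true size is unknown. For the compounds shown here, the new result adds a second sulfonyloxy group at this position: 4-methylphenyl in place of methyl on the sulfonyl sulfur, the one change between compound 1 and compound 4, still gives no definite number, as both compounds stop at a limit of the assay. The steps from compound 1 and from compound 2 to compound 4 cannot be read because both ends of each are limits, and compound 3 remains the only compound with a number: the limit of > 20000 nM in this assay, at which 3 of the 4 values shown sit.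

The compounds shown leave open how far compound 1, compound 2 and compound 4 lie past that limit, so no order among them can be given. They also leave open how a longer chain such as (4-aminobutyl)amino, or a smaller group such as hydroxyl or methoxy, would read on this same aromatic carbon.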